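A few compounds are considered here, and "the series" means these few. Any claim that something is new, unique, unknown or untested is made for them only; others in the source may bear on it.

Compound 1 `Cc1nc(CS(=O)(=O)c2ccccc2)c([N+](=O)[O-])n1C`: > 846000 nM (a limit)
Compound 2 `Cc1nc(CS(=O)(=O)c2ccc(F)cc2)c([N+](=O)[O-])n1C`: > 797000 nM (a limit)
Compound 3 `Cc1nc(CS(=O)(=O)c2ccccc2)c([N+](=O)[O-])n1CCO`: > 768000 nM (a limit)

In an ADME assay on THP-1 cells (Homo sapiens) for cytotoxicity, read by flow cytometry and propidium iodide staining, with a stated time of 72 h (on this read-out lower numbers stand for stronger inhibition and higher numbers for weaker inhibition), compound 3 reads > 768000 nM and this is a limit, not a number. Compounds 1 and 2 also give only limits, so none of the three has a readable value. Compound 4 `Cc1nc(CS(=O)(=O)c2ccc(Br)cc2)c([N+](=O)[O-])n1CCO` carries bromo in place of hydrogen on an aromatic carbon. Among the measured compounds shown here, two measured steps bear on it: the fluoro change gives a step that the two limits leave unreadable from compound 1 to compound 2 and the hydroxymethyl change gives a step that the two limits leave unreadable from compound 1 to compound 3 and neither has a size. No step beyond the usual scatter is therefore expected in this assay although this expectation rests on little. The expected step is an at least 1.2-fold lower number from compound 3 to compound 4 (0.09 log units; that floor lies within the scatter) and it is only an estimate. For compound 4 the estimated value is 620000 nM with an expected range of 300000 nM to 900000 nM and a report of a limit alone is likely.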

Compound 4, half-maximal inhibitory concentration: 124000 nM
Beside the measured number, compound 4's estimate is 5.0-fold (0.70 log units) above it; the measured number lies below the stated range.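

In this assay, bromo in place of hydrogen on an aromatic carbon gives an at least 6.1-fold lower number from compound 3 to compound 4 (0.79 log units; beyond the scatter), so a change at this place on the ring can move the read-out. The steps among compound 1, compound 2 and compound 3 cannot be read, which leaves compound 4 as the only one of the four with an actual number. Compound 3 gave only a limit, so the new step is a minimum.

Going by these compounds, whether bromo would do the same on compound 1, which lacks the chain of compound 3, stays open. So does the effect of a chloro, a methoxy or an amine at this same place.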